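A few compounds are considered here, and "the series" means these few. Any claim that something is new, unique, unknown or untested is made for them only; others in the source may bear on it.

Measured compounds:

Compound 1, `COc1cccc2sc(NC(=O)c3ccc(C(F)(F)F)cc3)nc12`, in a functional assay on SK-HEP1 cells (Homo sapiens) for antiproliferative activity, read by sulforhodamine B assay (a lower number here means a stronger inhibitor of growth, a higher number a weaker inhibitor of growth), compound 1 gives > 10 ug/mL, which is a limit of the assay and not a number.

Compound 2, `COc1cccc2sc(NC(=O)c3ccc([N+](=O)[O-])cc3)nc12`, in this assay compound 2 gives > 10 ug/mL, again a limit rather than a number.

Compound 3, `COc1ccc2sc(NC(=O)c3ccc([N+](=O)[O-])cc3)nc2c1`, in this assay compound 3 gives > 10 ug/mL, also a limit.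

Compound 1 and compound 2 share a core and differ in one place: trifluoromethyl in place of nitro on an aromatic carbon. Because both values are limits, the step that the two limits leave unreadable from compound 2 to compound 1 cannot be read; it is only known that neither compound reaches a measurable number. Compound 3 carries the same atoms as compound 2, joined differently, and the difference between the two cores is not broken down here. Within the data shown here, the one thing the three measurements share is the limit of > 10 ug/mL in this assay, at which 3 of the 3 values shown sit, so no ordering among them can be drawn.

Compound 4, `COc1ccc2sc(NC(=O)c3ccc(C(F)(F)F)cc3)nc2c1`, has not yet been measured in this assay. It is built from compound 3 by trifluoromethyl in place of nitro on an aromatic carbon, the same change that turns compound 2 into compound 1, at the same place. Since that earlier change is unreadable, and compound 3 sits at > 10 ug/mL, the step from compound 3 to compound 4 is expected to be small or unreadable, a step that the limit leaves unreadable from compound 3 to compound 4. Compound 4 is therefore expected to give about 15 ug/mL in this assay, with a plausible range from 7 ug/mL to 40 ug/mL, and most likely only a limit will be reported.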

Compound 4, concentration for 50% growth inhibition: > 10 ug/mL
Compound 4 gave a limit, no number; the forecaster's own chance of this, stated with the estimate: 80%; the middle value is on the limit's open side.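

In this assay compound 4 gives > 10 ug/mL, which is a limit and not a number. Among these compounds, the step from compound 3 to compound 4, like the one from compound 2 to compound 1, cannot be read, so trifluoromethyl in place of nitro yields no new comparison. How strongly these four compounds inhibit growth, and how they rank, stays open because they all share one result: the limit of > 10 ug/mL in this assay, at which 4 of the 4 values shown sit.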